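Demethylating the methoxyphenyl amine in the shared core

The source may hold more compounds than are shown below. What is called first, only, known or untested is meant among the compounds shown, and "the series" means these compounds.

Measured compounds in a functional assay on MCF7 cells (Homo sapiens) for inhibition, read by colorimetric assay and MTT assay, with a stated time of 72 h; on this read-out higher numbers stand for weaker inhibition and lower numbers for stronger inhibition:
Compound 1 `Cc1ccc(-c2nnc(Nc3csc(-c4ccccc4)c3)s2)cc1`: 34000 nM
Compound 2 `COc1ccc(-c2nnc(Nc3csc(-c4ccccc4)c3)s2)cc1`: 60000 nM
Compound 3 `COc1ccc(-c2nnc(Nc3csc(-c4ccc(C)cc4)c3)s2)cc1`: "not determined" (no result reported)

Compound 2 holds the highest of the two numbers reported in this assay; its nearest neighbour is compound 1, and the step of a 1.8-fold higher number from compound 1 to compound 2 (0.25 log units; within the scatter) is within the scatter. Compound 3 carries no result.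

Compound 4 `Oc1ccc(-c2nnc(Nc3csc(-c4ccccc4)c3)s2)cc1` differs from compound 2 by hydrogen in place of methyl on an oxygen on an aromatic ring. Among the compounds with values here, no measured step removes a methyl from an oxygen, so only the single step of a 1.8-fold higher number from compound 1 to compound 2 (0.25 log units; within the scatter) gives a sense of scale, and it was small. Compound 4 is therefore expected to show no change beyond the scatter in this assay, a step of about a 1.2-fold lower number from compound 2 to compound 4 (0.08 log units; within the scatter). Compound 4 is estimated at 50000 nM, with a range from 18000 nM to 140000 nM.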

Compound 4, half-maximal inhibitory concentration: 24000 nM
Compound 4: middle estimate off by 2.1-fold (0.32 log units), on the high side, and the stated range covers the measured number.
By their numbers in this assay, from the lowest: compounds 4, 1 and 2 (each within the scatter of the next, the first and the last beyond it).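

In this assay, within the data shown here, the change from 4-methoxyphenyl to 4-hydroxyphenyl gives the only step that lies beyond the scatter, a 2.5-fold lower number from compound 2 to compound 4 (0.40 log units; beyond the scatter). Hydroxy in place of the methyl on the aromatic carbon stays within the scatter, a 1.4-fold lower number from compound 1 to compound 4 (0.15 log units; within the scatter), so this position separates only the methoxy and hydroxy compounds. Nothing available bears on the reason for this difference. From the compounds shown here alone, whether an amine or a carboxylic acid at this position would move the number further remains open, as does the effect of an ethoxy group.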